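The compounds below may be only part of what the source reports. "The series", "measured", "known", "first", "only" and "open" are said of these compounds alone.

Values in a functional assay on MCF7 cells (Homo sapiens) for antiproliferative activity, read by MTT assay, with a stated time of 6 days; on this read-out lower numbers stand for stronger inhibition and higher numbers for weaker inhibition:
- Compound 1 `O=C1C=C[C@@H](OCc2ccccc2)[C@@H]([C@@H](COC(=O)/C=C/c2ccccc2)OCc2ccccc2)O1`: 2570 nM
- Compound 2 `CC(=O)O[C@@H]1C=CC(=O)O[C@@H]1[C@@H](COC(=O)/C=C/c1ccc(F)cc1)OC(C)=O`: 4260 nM
- Compound 3 `COc1cccc(C(=O)OC[C@@H](OC(=O)c2cccc(OC)c2)[C@H]2OC(=O)C=C[C@H]2OC(=O)c2cccc(OC)c2)c1`: 30300 nM

The values of compound 1 and compound 2 lie within the usual scatter of each other. Compound 3 stands well apart from compound 1, beyond the scatter, on the side of weaker inhibition.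

The next compound to be tested is compound 4 `O=C1C=C[C@@H](OCc2ccccc2)[C@@H]([C@@H](CO)OCc2ccccc2)O1`. It carries hydrogen in place of (2-phenylethenyl)carbonyl on an oxygen on a saturated carbon of compound 1 (hydrogen in place of (2-phenylethenyl)carbonyl on an oxygen on a saturated carbon), so that ((2-phenylethenyl)carbonyl)oxy becomes hydroxy.

Going by the values given here, no two measured compounds differ in one place only, so no measured step guides this expectation. Compound 3, at 30300 nM, also lacks the (2-phenylethenyl)carbonyl group, but it differs from compound 1 elsewhere too, so it offers only a weak hint. A moderate step toward weaker inhibition in this assay is expected, estimated as a 2.7-fold higher number from compound 1 to compound 4 (0.44 log units; beyond the scatter). Compound 4 is expected at 7000 nM, with an estimated range of 2000 nM to 25000 nM.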

Compound 4, half-maximal inhibitory concentration: 17600 nM
The estimate for compound 4 lay 2.5-fold (0.40 log units) below the measured number; low and high end bracket the measured number.
By their numbers in this assay, from the lowest: compounds 1 and 2 (each within the scatter of the next); then compounds 4 and 3 (each within the scatter of the next).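

In this assay, replacing the (2-phenylethenyl)carbonyl on an oxygen on a saturated carbon with hydrogen gives a 6.8-fold higher number from compound 1 to compound 4 (0.84 log units; beyond the scatter). This is the first reading of a single change among these compounds, and it lies beyond the scatter, so inhibition at this place depends measurably on the (2-phenylethenyl)carbonyl group. The group is not essential to activity, however, as compound 4 with its hydroxy still gives 17600 nM as a finite value in this assay.

As far as these compounds go, it remains open whether the whole (2-phenylethenyl)carbonyl group is needed, or whether a shorter acyl chain such as propanoyl, a plain benzoyl or an amine at this place would serve equally well. Nothing measured here explains the size of this step.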